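The source may hold more compounds than are shown below. What is called first, only, known or untested is meant among the compounds shown, and "the series" means these compounds.

Series notes. Compound 1 `CCCCCCn1cnc2c(Nc3ccc(O)cc3)nc(N[C@H]3CC[C@H](N)CC3)nc21` gives 24700 nM in a functional assay on HCC827 cells (Homo sapiens) for inhibition, read by fluorescence, with a stated time of 72 h (a lower number here means a stronger inhibitor of growth, a higher number a weaker inhibitor of growth), and stands second highest of the three numbers in hand: compound 3 `N[C@H]1CC[C@H](Nc2nc(Nc3ccc(O)cc3)c3ncn(C4CCCCC4)c3n2)CC1` gives 32500 nM and compound 2 `CC(C)=CCC/C(C)=C/Cn1cnc2c(Nc3cccc(Cl)c3)nc(N[C@H]3CC[C@H](N)CC3)nc21` gives 18200 nM, and both gaps from compound 1 lie within the scatter. Among the compounds with values here, the only single-point step measured, a 1.3-fold higher number from compound 1 to compound 3 (0.12 log units; within the scatter), changes the chain on the aromatic nitrogen, a different part of the molecule. Compound 4 `CCCCCCn1cnc2c(Nc3cc(OC)cc(OC)c3)nc(N[C@H]3CC[C@H](N)CC3)nc21` differs from compound 1 by 3,5-dimethoxyphenyl in place of 4-hydroxyphenyl on a nitrogen on an aromatic ring. Within the data shown here, no measured step touches this change, and compound 2 differs from compound 1 in two places, so its value cannot be read as a step. With nothing to push the number either way, compound 4 is expected near compound 1 with a wide range, a step of a 1.0-fold higher number from compound 1 to compound 4 (0.01 log units; within the scatter). Compound 4 is therefore estimated at 25000 nM, between 7000 nM and 90000 nM.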

Compound 4, concentration for 50% growth inhibition: 9100 nM
Compound 4: the middle estimate sits 2.7-fold (0.44 log units) above what was measured; measured number inside the range.
By their numbers in this assay, from the lowest: compounds 4, 2, 1 and 3 (each within the scatter of the next, the first and the last beyond it).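

In this assay, within the data shown here, the change from 4-hydroxyphenyl to 3,5-dimethoxyphenyl on a nitrogen on an aromatic ring gives the only step here beyond the scatter (a 2.7-fold lower number from compound 1 to compound 4 (0.43 log units; beyond the scatter)), so this position can move the number, though modestly. The step changes both the groups on the ring and where they sit, and a single step cannot separate the two. No evidence bears on why the number moves. Open, going by these compounds, is whether 4-methoxyphenyl or 3,5-dihydroxyphenyl would give a similar number. Also open, on these data alone, is how an amine or a carboxylic acid on this ring would read.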